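This account rests on a few compounds, and the source may have more. Where it says the series, first, only, none or still open, it means among the compounds named here.

Measured compounds:
compound 1 `CCCCCCCCCCCCCCCCCCNC(=O)[C@H]1CSC(CCCCCCCCCCCC)N1` – 11900 nM
compound 2 `CCCCCCCCCCCCCCCCCCNC(=O)[C@H]1CSC(c2cccc(O)c2)N1` – 1700 nM

Both compounds were tested in a functional assay on LNCaP cells (Prostate gland, Homo sapiens) for antiproliferative activity, read by sulforhodamine B assay; a lower number here means a stronger inhibitor, a higher number a weaker inhibitor. Compound 2 gives the lowest of the two numbers, with 1700 nM; its nearest neighbour is compound 1, which gives 11900 nM. Going by the values given here, the one step between them, a 7.0-fold lower number from compound 1 to compound 2 (0.85 log units; beyond the scatter), was a modest gain and is the only measured step available.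

Compound 3 `CCCCCCCCCCCCCCCCCCNC(=O)[C@H]1CSC(c2cc(F)cc(F)c2)N1` has not yet been measured. It differs from compound 2 in one place: 3,5-difluorophenyl in place of 3-hydroxyphenyl on a saturated ring carbon. The step from compound 1 to compound 2 shows that an aromatic ring on this saturated ring carbon gives a lower number than a dodecyl chain, but nothing measured here compares one aromatic ring with another, so that step bears on compound 3 only in that the aromatic ring stays. Among the compounds with values here, no measured step covers the loss of the hydroxyl or the entry of the two fluorines.

Compound 3 is therefore expected to stay in the range of compound 2, with a small step of a 1.8-fold higher number from compound 2 to compound 3 (0.25 log units; within the scatter) toward a higher number that may lie within the scatter. The estimate for compound 3 is 3000 nM, with a range from 1000 nM to 9000 nM.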

Compound 3, half-maximal inhibitory concentration: 11200 nM
Compound 3: the middle estimate sits 3.7-fold (0.57 log units) below what was measured; measured number above the stated range.
By their numbers in this assay, from the lowest: compound 2; then compounds 3 and 1 (each within the scatter of the next).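

In this assay, the swap on this saturated ring carbon gives a 6.6-fold higher number from compound 2 to compound 3 (0.82 log units; beyond the scatter) and so shows that an aromatic ring alone does not secure the lower number of compound 2. The reading a 1.1-fold lower number from compound 1 to compound 3 (0.03 log units; within the scatter) leaves 3,5-difluorophenyl and dodecyl level within the scatter in this assay, so among the three groups shown, only 3-hydroxyphenyl goes with the lower number, and the earlier gain cannot be credited to aromatic rings in general. No measured evidence on the reason for this difference is available here.

The swap removes the hydroxyl and brings in fluorine in a single step, and the compounds shown cannot divide the effect between those two changes. Also open, going by these compounds, is how an unsubstituted phenyl ring, or a ring carrying a methoxy group or an amine in place of the hydroxyl, would compare on this same core.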